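A few compounds are considered here, and "the series" means these few. Any claim that something is new, unique, unknown or untested is made for them only; others in the source may bear on it.

In a physicochemical assay, with a stated time of 30 min (on this read-out lower numbers stand for stronger inhibition and higher numbers for weaker inhibition), compound 1 `CCOc1ccc(NC(=O)C2Cc3cc(OC)c(OC)cc3C2=O)cc1` gives 48.2 ug/mL and compound 2 `COc1cc2c(cc1OC)C(=O)C(C(=O)Nc1ccc(F)cc1)C2` gives 55 ug/mL while compound 3 `COc1cc2c(cc1OC)C(=O)C(C(=O)Nc1ccc(Cl)cc1)C2` gives 56.8 ug/mL and so stands within the scatter of both. Within the data shown here, compound 4 `COc1cc2c(cc1OC)C(=O)C(C(=O)Nc1cccc(Cl)c1)C2` carries 3-chlorophenyl in place of 4-chlorophenyl on an amide-type nitrogen and no measured step makes a change of this kind. The closest measured steps are a 1.1-fold higher number from compound 1 to compound 2 (0.06 log units; within the scatter) and a 1.2-fold higher number from compound 1 to compound 3 (0.07 log units; within the scatter) and also a 1.0-fold higher number from compound 2 to compound 3 (0.01 log units; within the scatter) and all of them are small. No step beyond the scatter is therefore expected in this assay and no direction can be told from these data. The estimated step is a 1.0-fold lower number from compound 3 to compound 4 (0.01 log units; within the scatter) and no more than that is expected. Compound 4 is expected at 55 ug/mL with an estimated range of 30 ug/mL to 100 ug/mL in this measurement.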

Compound 4, half-maximal inhibitory concentration: 76.3 ug/mL
Estimate against measurement, compound 4: 1.4-fold (0.14 log units) below, and the stated range covers the measured number.
By their numbers in this assay, from the lowest: compounds 1, 2, 3 and 4 (each within the scatter of the next).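

In this assay, 3-chlorophenyl in place of 4-chlorophenyl on the amide-type nitrogen gives a 1.3-fold higher number from compound 3 to compound 4 (0.13 log units; within the scatter) and 3-chlorophenyl in place of 4-fluorophenyl gives a 1.4-fold higher number from compound 2 to compound 4 (0.14 log units; within the scatter) and so both steps stay within the scatter. Among these compounds, the earlier compounds exchanged only one group for another on an aromatic carbon, whereas compound 4 shows that relocating the chloro group also gives no step that can be told from the scatter. No evidence bears on this result. The compounds shown leave open whether an amine or a carboxylic acid on this aromatic ring would give a step beyond the scatter.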